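The compounds below may be only part of what the source reports. "The series", "measured", "known", "first", "only" and "open" are said of these compounds alone.

Compound 1 `COc1c(OC)c(OC(=O)C(C)(C)C)c2ccccc2c1OC(=O)C(C)(C)C`: 5.69
Compound 2 `CC(C)(C)C(=O)Oc1c(Oc2ccccc2)c(Oc2ccccc2)c(OC(=O)C(C)(C)C)c2ccccc12`: 7.8

Both compounds were measured in a physicochemical assay for lipophilicity; a higher number here means a more lipophilic compound, a lower number a more polar compound. Compound 1 has the lower of the two values, and the gap up to compound 2 lies beyond the usual scatter of such measurements. These two compounds differ in more than one place, so their gap cannot be traced to any single structural change. Going by the values given here, no pair measured so far differs in one place only, which means that no measured step is available as a guide.

The next compound to be measured is compound 3 `COc1c(OC)c(OC(=O)C(C)(C)C)c2c(Cl)cccc2c1OC(=O)C(C)(C)C`. It is compound 1 with a single change: chloro in place of hydrogen on an aromatic carbon. In words, this is chloro in place of hydrogen on an aromatic carbon, and the rest of the structure stays the same.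

Among the compounds with values here, with no measured step to lean on, this expectation rests on the structural change alone. A moderate rise in this assay is expected, probably just beyond the scatter. The expected step is a number 0.61 log units higher from compound 1 to compound 3 (beyond the scatter). Compound 3 is estimated at 6.3, with an expected range from 5.9 to 6.8.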

Compound 3, partition coefficient: 6.1
Compound 3: the middle estimate sits 0.20 log units above what was measured; low and high end bracket the measured number.
By their numbers in this assay, from the lowest: compound 1; then compound 3; then compound 2.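

In this assay, chloro in place of hydrogen on an aromatic carbon of the core of compound 1 gives a number 0.41 log units higher from compound 1 to compound 3 (beyond the scatter) and leaves the rest of the structure as it was. Going by these compounds alone, this is the first difference here that can be tied to one place in the structure, whereas the earlier pair differed in more than one place and offered no such reading. The position concerned lies on a six-membered aromatic ring of carbon only, ortho to a fused ring and meta to a fused ring, and the entry of a single chlorine atom there moves the number by a modest amount that still lies beyond the usual scatter.

No measurement shown explains why this step has the size it has. On these data alone, it remains open whether bromo, an amine or a carboxylic acid at this same position would shift the number in the same direction, and whether chloro on another aromatic carbon of the core would give a similar step, since a single step at a single position establishes no trend.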